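Swapping methylsulfanyl for iodo on the aryl ring

The compounds below may be only part of what the source reports. "The series", "measured", "known", "first", "only" and "open" are said of these compounds alone.

Measured compounds:
compound 1 `CCCc1cc(N)c2cc(NC(=O)/C=C/c3ccc(C(C)(C)C)cc3)ccc2n1`: 910 nM
compound 2 `CCCc1cc(N)c2cc(NC(=O)/C=C/c3ccc(SC)cc3)ccc2n1`: 71 nM

In a functional assay on HEK293 cells for activation of melanin-concentrating hormone receptor 1 (Homo sapiens), read by inositol phosphate accumulation (on this read-out lower numbers stand for an effect already at smaller amounts and higher numbers for an effect only at larger amounts of compound), compound 2 gives 71 nM, while compound 1 gives 910 nM. Going by the values given here, compound 2 therefore holds the lower of the two numbers, and the only measured step, a 13-fold lower number from compound 1 to compound 2 (1.11 log units; beyond the scatter), separates it from compound 1 by a large margin.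

Compound 3 `CCCc1cc(N)c2cc(NC(=O)/C=C/c3ccc(I)cc3)ccc2n1` keeps the whole of compound 2 except for one change: iodo in place of methylsulfanyl on an aromatic carbon. Among the compounds with values here, the single step that bears on this position, a 13-fold lower number from compound 1 to compound 2 (1.11 log units; beyond the scatter), shows that the group on this carbon can move the number strongly, but it compares tert-butyl with methylsulfanyl and gives no direct precedent for iodo, which is a single heavy atom without acceptors. With no closer comparison at hand, compound 3 is expected to stay near compound 2, with a step of a 1.5-fold higher number from compound 2 to compound 3 (0.19 log units; within the scatter) that need not exceed the scatter. The estimate for compound 3 is 110 nM, within a range from 30 nM to 400 nM.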

Compound 3, half-maximal effective concentration: 280 nM
For compound 3 the middle estimate is 2.5-fold (0.41 log units) below the measured one; measured number inside the range.
By their numbers in this assay, from the lowest: compound 2; then compound 3; then compound 1.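

In this assay the exchange of methylsulfanyl for iodo is not neutral: the result is a 3.9-fold higher number from compound 2 to compound 3 (0.60 log units; beyond the scatter) and shows that, on this aromatic carbon, iodo does not match methylsulfanyl. Iodo still retains part of the advantage over tert-butyl, with a 3.3-fold lower number from compound 1 to compound 3 (0.51 log units; beyond the scatter), so the three groups fall into a graded order rather than one favourable group and two poor ones. Nothing available explains why the groups rank in this order.

Whether that order extends to other groups on this carbon stays open, since the compounds shown include no amine, carboxylic acid or methoxy group there. They also leave open how a longer chain on the sulfur, such as ethylsulfanyl, would compare with methylsulfanyl.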